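The source may hold more compounds than are shown below. What is called first, only, known or untested is meant among the compounds shown, and "the series" means these compounds.

Three compounds that share a core were measured in a functional assay on MCF7 cells (Homo sapiens) for antiproliferative activity, read by MTT assay, with a stated time of 72 h; on this read-out lower numbers stand for stronger inhibition and higher numbers for weaker inhibition. Compound 1 `COc1cc2c(Nc3cccc(C#N)c3)ncnc2cc1OCCCN1CCCCC1` gives 44800 nM in this assay. Compound 2 `COc1cc2c(Nc3cccc(C#N)c3)ncnc2cc1OCCCN1CCC(C)CC1` differs from compound 1 by methyl in place of hydrogen on a saturated ring carbon; in this assay compound 2 gives 24400 nM, and the step is a 1.8-fold lower number from compound 1 to compound 2 (0.26 log units; within the scatter). Compound 3 `COc1cc2c(Nc3ccccc3C#N)ncnc2cc1OCCCN1CCCCC1` carries the other core, the difference being (2-cyanophenyl in place of 3-cyanophenyl on a nitrogen on an aromatic ring); in this assay compound 3 gives 15200 nM, and the step is a 2.9-fold lower number from compound 1 to compound 3 (0.47 log units; beyond the scatter). The values of compound 2 and compound 3 lie within the scatter of each other, so no order between them can be read.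

Compound 4 `COc1cc2c(Nc3ccccc3C#N)ncnc2cc1OCCCN1CCC(C)CC1` has not yet been measured. It differs from compound 3 by methyl in place of hydrogen on a saturated ring carbon, and this is the same change as the one from compound 1 to compound 2, the place being described in the same words in both cases; it occurs twice among these compounds. Because that change gave a 1.8-fold lower number from compound 1 to compound 2 (0.26 log units; within the scatter), a step within the scatter, a step of about the same size is expected on the core of compound 3 as well. The expected step is a 1.5-fold lower number from compound 3 to compound 4 (0.18 log units; within the scatter). This rests on a single earlier instance of the change, made on a different core, so the range is kept wide. Compound 4 is therefore expected to give about 10000 nM in this assay, estimated to fall between 5000 nM and 25000 nM.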

Compound 4, half-maximal inhibitory concentration: 31900 nM
For compound 4 the middle estimate is 3.2-fold (0.50 log units) below the measured one; the whole stated range lies below it.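

In this assay, the change from piperidin-1-yl to 4-methylpiperidin-1-yl did not carry over from the core of compound 1 to the core of compound 3, where it gives a 2.1-fold higher number from compound 3 to compound 4 (0.32 log units; beyond the scatter), and the two steps differ: the same change on two cores in this assay, a 1.8-fold lower number (0.26 log units; within the scatter) from compound 1 to compound 2 and a 2.1-fold higher number (0.32 log units; beyond the scatter) from compound 3 to compound 4, 3.9-fold (0.59 log units) apart, beyond the scatter of two such steps. The other change in the set also depends on its surroundings: with 4-methylpiperidin-1-yl in place, 2-cyanophenyl in place of 3-cyanophenyl gives a 1.3-fold higher number from compound 2 to compound 4 (0.12 log units; within the scatter), a step within the scatter that differs from the one seen with piperidin-1-yl: the same change on two cores in this assay, a 2.9-fold lower number (0.47 log units; beyond the scatter) from compound 1 to compound 3 and a 1.3-fold higher number (0.12 log units; within the scatter) from compound 2 to compound 4, 3.9-fold (0.59 log units) apart, beyond the scatter of two such steps. These four compounds thus show that the two changes do not simply add in this assay, so a step measured on one core could not be transferred to the other here, but they do not show why this happens, and each comparison rests on one pair of steps, so no general rule for the series follows.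

The compounds shown leave open whether an ethyl or a hydroxyl group in the place of the methyl would also behave differently on the two cores. They also leave open whether a chloro group in place of the nitrile on the phenyl ring would alter how the change to 4-methylpiperidin-1-yl carries over.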